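A few compounds are considered here, and "the series" means these few. Any claim that something is new, unique, unknown or untested is made for them only; others in the source may bear on it.

In a functional assay on HeLa S3 cells (Homo sapiens) for antiproliferative activity, read by XTT assay, with a stated time of 72 h (on this read-out higher numbers stand for weaker inhibition and lower numbers for stronger inhibition), compound 1 `C#Cc1cn([C@@H]2O[C@H](CO)[C@@H](O)[C@H]2O)c2ncnc(C)c12` gives 14700 nM. Compound 3 `Cc1ncnc2c1c(-c1cccs1)cn2[C@@H]1O[C@H](CO)[C@@H](O)[C@H]1O` reaches only a limit of this assay, > 15000 nM. Compound 2 `COc1nc(N)nc2c1c(-c1cccs1)cn2[C@@H]1O[C@H](CO)[C@@H](O)[C@H]1O` also reaches only a limit of this assay, > 20000 nM. The difference between the cores of compound 2 and compound 3 is not broken down here. The change ethynyl in place of thiophen-2-yl on an aromatic carbon produced an at least 1.0-fold lower number from compound 3 to compound 1 (0.00 log units; that floor lies within the scatter), a step that starts from the limit of the limit of > 15000 nM in this assay, at which 1 of the 3 values shown sits, and therefore sets only a floor. The same change, (ethynyl in place of thiophen-2-yl on an aromatic carbon), leads to compound 4 `C#Cc1cn([C@@H]2O[C@H](CO)[C@@H](O)[C@H]2O)c2nc(N)nc(OC)c12`, not yet measured in this assay. Compound 4 is expected to give 20000 nM in this assay. Within the data shown here, the step that this estimate means, a number no higher from compound 2 to compound 4 (the limit leaves the size open), is expected to be small because the only measured instance, an at least 1.0-fold lower number from compound 3 to compound 1 (0.00 log units; that floor lies within the scatter), began at a limit and offers no sign of a large gain.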

Compound 4, half-maximal inhibitory concentration: > 20000 nM
Compound 4: only a limit was reported (the forecaster's own chance of this, stated with the estimate: 55%); the middle value lies on the limit itself.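

Compound 2 and compound 4 both stand only at a limit of this assay, so the step between them cannot be read. The compounds shown leave open whether ethynyl in place of thiophen-2-yl changes the number at all on this core.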